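Aryl swap on the triazole nitrogen of a spiro-oxindole series

This account rests on a few compounds, and the source may have more. Where it says the series, first, only, none or still open, it means among the compounds named here.

Compound 1 `Cc1cccc(-n2nncc2CN2C(=O)C3(C(C#N)=C(N)Oc4c3c3nc5ccccc5nc3c3ccccc43)c3ccccc32)c1` in a functional assay on A549 cells (Homo sapiens) for antiproliferative activity, read by MTT assay, with a stated time of 48 h (on this read-out higher numbers stand for weaker inhibition and lower numbers for stronger inhibition), gives 39600 nM.
Compound 2 `CCOc1ccc(-n2nncc2CN2C(=O)C3(C(C#N)=C(N)Oc4c3c3nc5ccccc5nc3c3ccccc43)c3ccccc32)cc1` in this assay gives 25200 nM.
Compound 3 `Cc1ccccc1-n1nncc1CN1C(=O)C2(C(C#N)=C(N)Oc3c(N)cc4nc5ccccc5nc4c32)c2ccccc21` in this assay gives 31700 nM.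

Compound 3 stands second highest of the three values shown; its nearest neighbour is compound 1, and the two lie within the scatter of each other, as do compound 3 and compound 2, so no order among the three can be read from these numbers.

Compound 4 `N#CC1=C(N)Oc2c(N)cc3nc4ccccc4nc3c2C12C(=O)N(Cc1cnnn1-c1ccc(F)cc1)c1ccccc12` has not yet been measured. It differs from compound 3 in one place: 4-fluorophenyl in place of 2-methylphenyl on an aromatic nitrogen. The shared core, with its amino substituent, is kept unchanged.

For the measured compounds named here, one measured step bears on this change, an exchange of the aryl group on the same triazole nitrogen: a 1.6-fold lower number from compound 1 to compound 2 (0.20 log units; within the scatter). That exchange moved the value by less than the scatter, which gives no ground to expect the present exchange to do more.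

Compound 4 is therefore expected to sit close to compound 3, with a step of a 1.1-fold lower number from compound 3 to compound 4 (0.02 log units; within the scatter) that stays within the scatter. The estimate for compound 4 is 30000 nM, with a range from 12000 nM to 75000 nM.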

Compound 4, half-maximal inhibitory concentration: > 50000 nM
Compound 4 was reported as a limit; the forecaster's own chance of this, stated with the estimate: 10%; middle value at least 1.6-fold (0.22 log units) away from the limit.
By their numbers in this assay, from the lowest: compounds 2, 3 and 1 (each within the scatter of the next). At a limit, above all of these: compound 4.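

In this assay compound 4 gives > 50000 nM, which is a limit of the assay and not a number. The step, an at least 1.5-fold higher number from compound 3 to compound 4 (0.19 log units; that floor lies within the scatter), has a floor that still lies within the scatter, so it does not establish a real loss, but unlike the earlier exchange on the triazole nitrogen, a 1.6-fold lower number from compound 1 to compound 2 (0.20 log units; within the scatter), it has no upper bound and the true gap may be much larger. What this adds is that an aryl exchange at this position, with the same count of heavy atoms entering and leaving, can carry a compound to the assay's limit, which only this compound among those shown reaches: the limit of > 50000 nM in this assay, at which 1 of the 4 values shown sits.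

The change replaces 2-methylphenyl with 4-fluorophenyl in one move, so the compounds shown cannot separate the loss of the methyl group from the arrival of the fluorine, and how far compound 4 truly lies from compound 3 remains unknown. Also open, going by these compounds, is how the same core would respond to unsubstituted phenyl, 2-fluorophenyl or 4-methylphenyl on this nitrogen, or to an aryl ring bearing an amine or a carboxylic acid.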